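Removing the Methoxyethylamino Side Chain: What to Expect

The source may report more compounds than this note shows. Statements on the series, on what has been measured and on what is new or still open speak of the compounds shown alone.

Measured so far:
Compound 1, `COCCNc1nc(C)cc2c1c(N)nn2C`: -4%
Compound 2, `COCCNc1nc(-c2ccccc2)cc2c1c(N)nn2C`: -3%

Both compounds were tested in an assay on isolated protein for inhibition of ribosomal protein S6 kinase alpha-1 (Homo sapiens), read by mobility shift assay, tested at 30 uM; a lower number here means less inhibition, a higher number more inhibition at the concentration tested (going by the name of the read-out). Compound 1 gives -4% in this assay, while compound 2 gives -3%. Compound 2 holds the higher of the two numbers, but the step of a number 1 percentage points higher from compound 1 to compound 2 (within the scatter) lies within the scatter, so the two compounds cannot be told apart; both sit near zero, which means essentially no inhibition at the tested concentration.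

The next compound, compound 3, `Cn1nc(N)c2cnc(-c3ccccc3)cc21`, is related to compound 2 by a single change: hydrogen in place of (2-methoxyethyl)amino on an aromatic carbon.

Within the data shown here, no measured step bears directly on this change. Among the measured compounds shown here, the only step recorded, a number 1 percentage points higher from compound 1 to compound 2 (within the scatter), concerns a different position and was within the scatter. With both measured compounds showing no inhibition, and no sign that any part of this core drives inhibition here, the expectation for compound 3 is no step beyond the scatter. Compound 3 is therefore estimated at -2%, ranging from -15% to 12%. This amounts to an expected step of a number 1 percentage points higher from compound 2 to compound 3 (within the scatter), within the scatter.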

Compound 3, a percentage reported as inhibition, at one concentration (the size of the read-out at that concentration, not a potency): 2%
Beside the measured number, compound 3's estimate is 4 percentage points below it; the range from low to high includes it.
By their numbers in this assay, from the lowest: compounds 1, 2 and 3 (each within the scatter of the next).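

In this assay, replacing the (2-methoxyethyl)amino group with hydrogen on the aromatic carbon next to the ring nitrogen gives a number 5 percentage points higher from compound 2 to compound 3 (within the scatter). Among these compounds, this is the first change at this position, and it shows that the whole side chain can be removed without a shift beyond the scatter, with compound 3 still near zero at 2%. Among the compounds shown here, the result has limited reach, however: compound 2 had almost no inhibition to lose, so a flat step says only that the numbers of these two compounds are level in this assay, and no evidence is available to explain the result further.

The compounds shown leave open whether any group at this position can produce real inhibition, since only hydrogen and (2-methoxyethyl)amino appear there. A simple amine, a longer chain ending in a carboxylic acid, or a morpholine ring at the same carbon could show whether this position matters at all, or whether the number stays level in this assay whatever is attached to the shared core.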